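A few compounds are considered here, and "the series" means these few. Any claim that something is new, unique, unknown or untested is made for them only; others in the source may bear on it.

Measured compounds in a functional assay on DU-145 cells (Homo sapiens) for cytotoxicity, read by MTT assay, with a stated time of 72 h; a lower number here means a stronger inhibitor, a higher number a weaker inhibitor:
compound 1 `COc1cc(/C(=C\c2cn(C(C)=O)c3ccc(OCc4ccccc4)cc23)C(=O)O)cc(OC)c1OC` — 950 nM
compound 2 `COc1ccc(/C(=C\c2c[nH]c3ccc(OCc4ccccc4)cc23)C(=O)O)cc1` — 38100 nM
compound 3 `COc1ccc(Cn2cc(/C=C(/C(=O)O)c3ccccc3)c3cc(OCc4ccccc4)ccc32)cc1` — 860 nM

Among these three numbers compound 1 stands second highest in this assay. Compound 1 and compound 3 lie within the scatter of each other, so no order can be read between them. Compound 2, which differs from compound 1 in more than one place, gives a far higher number, and the two values show only that gap.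

Compound 4 `COc1ccc(OC)c(/C(=C\c2cn(C(C)=O)c3ccc(OCc4ccccc4)cc23)C(=O)O)c1` is not yet measured. It differs from compound 1 in one place: 2,5-dimethoxyphenyl in place of 3,4,5-trimethoxyphenyl on a double-bonded chain carbon bound to a carbonyl carbon and a double-bonded chain carbon. Going by the values given here, no measured pair shows this change, so the size of the step in this assay is uncertain; a move toward a higher number, beyond the scatter, is expected. For compound 4 the estimate is 3500 nM in this assay, with a range from 900 nM to 14000 nM. This estimate means an expected step of a 3.7-fold higher number from compound 1 to compound 4 (0.57 log units; beyond the scatter).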

Compound 4, half-maximal inhibitory concentration: 830 nM
For compound 4 the middle estimate is 4.2-fold (0.62 log units) above the measured one, outside the stated range (below it).
By their numbers in this assay, from the lowest: compounds 4, 3 and 1 (each within the scatter of the next); then compound 2.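

In this assay, this first pair to isolate the change gives a 1.1-fold lower number from compound 1 to compound 4 (0.06 log units; within the scatter), a step within the scatter. On a double-bonded chain carbon bound to a carbonyl carbon and a double-bonded chain carbon, 2,5-dimethoxyphenyl and 3,4,5-trimethoxyphenyl therefore cannot be told apart in this read-out. Nothing measured here explains this result. Going by these compounds, it remains open whether an unsubstituted phenyl, or a phenyl carrying a hydroxyl or a chlorine, would keep this value at the same place.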